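Swapping the pyrazole for an arylamine in a sulfonyl acylguanidine

The source may report more compounds than this note shows. Statements on the series, on what has been measured and on what is new or still open speak of the compounds shown alone.

Measured so far:
compound 1 `Cc1cc(Sc2ccccc2Cl)c(S(C)(=O)=O)cc1C(=O)N=C(N)N`: 14 nM
compound 2 `COc1cc(C)c(C(=O)N=C(N)N)cc1S(C)(=O)=O`: 16 nM
compound 3 `Cc1cc(-n2cccn2)c(S(C)(=O)=O)cc1C(=O)N=C(N)N`: 25 nM

These three compounds share one core and differ only in the group that sits ortho to the methylsulfonyl group. In a functional assay for inhibition of sodium/hydrogen exchanger (Oryctolagus cuniculus) (a higher number here means a weaker inhibitor, a lower number a stronger inhibitor), compound 3 gives the highest of the three numbers, but the gap to the others is small: a 1.8-fold higher number from compound 1 to compound 3 (0.25 log units; within the scatter) and a 1.6-fold higher number from compound 2 to compound 3 (0.19 log units; within the scatter), both within the scatter of repeat measurements, so the three cannot be ranked. The step of a 1.1-fold higher number from compound 1 to compound 2 (0.06 log units; within the scatter) is likewise flat.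

Compound 4 `Cc1cc(Nc2cccc(Cl)c2)c(S(C)(=O)=O)cc1C(=O)N=C(N)N` takes the next step: (3-chlorophenyl)amino in place of 1H-pyrazol-1-yl on an aromatic carbon. The closest guide is compound 1, whose (2-chlorophenyl)sulfanyl group also carries a chlorinated benzene ring at this position, and its step to compound 3 stayed within the scatter. Nothing measured here suggests that this position is sensitive, so compound 4 is expected to land near the others, with the step of a 1.7-fold lower number from compound 3 to compound 4 (0.22 log units; within the scatter) expected to stay within the scatter. The estimate for compound 4 in this assay is 15 nM, with a likely range from 6 nM to 40 nM.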

Compound 4, half-maximal inhibitory concentration: 33 nM
Estimate against measurement, compound 4: 2.2-fold (0.34 log units) below; the measured number falls inside the stated range.
By their numbers in this assay, from the lowest: compounds 1, 2, 3 and 4 (each within the scatter of the next, the first and the last beyond it).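

In this assay the larger (3-chlorophenyl)amino group, which brings a hydrogen-bond donor that 1H-pyrazol-1-yl lacks, cannot be told apart from that group: the step is a 1.3-fold higher number from compound 3 to compound 4 (0.12 log units; within the scatter) and so gives no sign that this swap matters. Compound 4 does give this position its first steps beyond the scatter, with a 2.1-fold higher number from compound 2 to compound 4 (0.31 log units; beyond the scatter) against methoxy and a 2.4-fold higher number from compound 1 to compound 4 (0.37 log units; beyond the scatter) against (2-chlorophenyl)sulfanyl, so the position is not entirely indifferent to its substituent, although both steps are modest. The measurements shown offer no explanation for these differences.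

The step against (2-chlorophenyl)sulfanyl changes both the linking atom and the place of the chlorine on the benzene ring, so a (2-chlorophenyl)amino group would be needed to separate the two changes. Also open is how far this tolerance extends, since a group such as a carboxylic acid or a simple alkylamine on this aromatic carbon would test the position with something quite different from the groups shown here.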